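A few compounds are considered here, and "the series" means these few. Any claim that something is new, unique, unknown or untested is made for them only; others in the source may bear on it.

Compound 1, `COc1cc(/C=C/C(=O)/C=C/c2ccccc2)ccc1OCc1cn(CCCCOc2cc(=O)oc3ccccc23)nn1`, gives 36% in a functional assay on THP-1 cells (Homo sapiens) for inhibition, read by sulforhodamine B assay, with a stated time of 48 h, tested at 50 uM; on this read-out higher numbers stand for more inhibition of growth at the one concentration tested and lower numbers for less inhibition of growth. Compound 2, `COc1cc(/C=C/C(=O)/C=C/c2cc(OC)c(OC)c(OC)c2)ccc1OCc1cn(CCCCOc2cc(=O)oc3ccccc23)nn1`, gives 65% in this assay. Compound 3, `COc1cc(/C=C/C(=O)/C=C/c2ccccc2)ccc1OCc1cn(CCCCCOc2cc(=O)oc3ccccc23)nn1`, gives 26% in this assay.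

Compound 2 differs from compound 1 by 3,4,5-trimethoxyphenyl in place of phenyl on a double-bonded chain carbon bound to a double-bonded chain carbon. This change made a step of a number 29 percentage points higher from compound 1 to compound 2 (beyond the scatter). Compound 3 carries a different core from compound 1; the difference between the two cores is not broken down here, and the two values of compound 1 and compound 3 lie within the usual scatter of each other.

Compound 4, `COc1cc(/C=C/C(=O)/C=C/c2cc(OC)c(OC)c(OC)c2)ccc1OCc1cn(CCCCCOc2cc(=O)oc3ccccc23)nn1`, differs from compound 3 by 3,4,5-trimethoxyphenyl in place of phenyl on a double-bonded chain carbon bound to a double-bonded chain carbon. The place of the change is the same as before, so this is the same change on the core of compound 3. Since the earlier step from compound 1 to compound 2 was a number 29 percentage points higher from compound 1 to compound 2 (beyond the scatter), a step of comparable size is expected from compound 3 to compound 4, namely a number 29 percentage points higher from compound 3 to compound 4 (beyond the scatter). Compound 4 is therefore estimated at 55%, with the likely range running from 35% to 75%.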

Compound 4, percent growth inhibition at one concentration: 55%
Estimate against measurement, compound 4: no gap at the digits printed; the range from low to high includes it.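

In this assay, 3,4,5-trimethoxyphenyl in place of phenyl gives a number 29 percentage points higher from compound 3 to compound 4 (beyond the scatter) and so carries over to the core of compound 3. The two steps match: the same change on two cores in this assay, a number 29 percentage points higher (beyond the scatter) from compound 1 to compound 2 and a number 29 percentage points higher (beyond the scatter) from compound 3 to compound 4, 0 percentage points apart, within the scatter of two such steps. This shows that the change transfers between these two closely related cores at the one concentration tested, but two cores cannot show that it would transfer to others, and the numbers do not explain why the step occurs.

From the compounds shown here alone, it remains open how a phenyl carrying an amine or a carboxylic acid would compare at this place. Going by these compounds, it is also open whether a longer chain in the core would leave the step intact.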